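This account rests on a few compounds, and the source may have more. Where it says the series, first, only, none or still open, it means among the compounds named here.

Measured so far:
compound 1 `COc1cccc(C(O)CCn2nc3c(Br)c(Br)c(Br)c(Br)c3n2)c1` — 22% in a functional assay on MCF7 cells (Homo sapiens) for antiproliferative activity, read by MTT assay, with a stated time of 24 h, tested at 50 uM; a higher number here means a weaker effect of the compound at the concentration tested, a lower number a stronger effect
compound 2 `C[C@H](O)CCn1nc2c(Br)c(Br)c(Br)c(Br)c2n1` — 105%

Compound 2 is the higher of the two numbers in this assay; compound 1 lies far below it, beyond the usual scatter. Compound 3 `OCC(O)Cn1nc2c(Br)c(Br)c(Br)c(Br)c2n1` has not been measured. It differs from compound 2 in one place: 1,2-dihydroxyethyl in place of 2-hydroxypropyl on a saturated chain carbon bound to an aromatic nitrogen. Among the compounds with values here, no pair differing in a single place has been measured, so the size of this step is unknown from the series itself. Compound 2 already sits at 105%, leaving little room upward. The expected step is a number 10 percentage points lower from compound 2 to compound 3 (within the scatter), not beyond the scatter. Compound 3 is estimated at 95% in this assay, range 70% to 115%.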

Compound 3, a percentage reported as activity, at one concentration (the size of the read-out at that concentration, not a potency): 98%
The estimate for compound 3 lay 3 percentage points below the measured number, and the stated range covers the measured number.
By their numbers in this assay, from the lowest: compound 1; then compounds 3 and 2 (each within the scatter of the next).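

In this assay, within the data shown here, the first single-place step on this chain reads a number 7 percentage points lower from compound 2 to compound 3 (within the scatter), so 1,2-dihydroxyethyl and 2-hydroxypropyl cannot be told apart here. The entering group carries 2 hydrogen-bond donors and 2 hydrogen-bond acceptors against 1 of each in the leaving group, and it lacks the defined stereocentre, yet the step stays within the scatter. No measurement at hand bears on the reason for this result. On these data alone, what an amine or a carboxylic acid would give on this saturated chain carbon remains open. As far as these compounds go, a longer chain without a hydroxyl group is equally open.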